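A few compounds are considered here, and "the series" means these few. Any claim that something is new, unique, unknown or untested is made for them only; others in the source may bear on it.

Measured so far:

compound 1 `CC(/C=C/CC(C)CCCC(C)C)=C\C(=O)OC(C)C`: 7.15
compound 2 `CSC(C)(C)CCCC(C)C/C=C/C(C)=C/C(=O)OC(C)C`: 6.77
compound 3 `COC(CCC(C)C/C=C/C(C)=C/C(=O)OC(C)C)C(C)(C)OC`: 4.75

These three compounds share one chain and differ only at its far end. In a physicochemical assay for lipophilicity (a lower number here means a more polar compound, a higher number a more lipophilic compound), compound 1 gives 7.15, the highest of the three numbers. The step of a number 0.38 log units lower from compound 1 to compound 2 (beyond the scatter) is a modest one, while the step of a number 2.40 log units lower from compound 1 to compound 3 (beyond the scatter) is a large one, and the step of a number 2.02 log units lower from compound 2 to compound 3 (beyond the scatter) is also large.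

Compound 4 `CCN(CC)C(=O)/C=C(C)/C=C/CC(C)CCCC(C)C` is not yet measured. It differs from compound 1 at the opposite end of the chain: diethylamino in place of isopropoxy on a carbonyl carbon. Among the measured compounds shown here, none of the measured steps touches the carbonyl carbon; all of them alter the saturated end of the chain, so no measured step bears directly on this change. The three values do show that the chain end shared by compound 1 and compound 4 tolerates only a limited range of change, and that the carbonyl end has not been varied at all among the measured compounds.

For the measured compounds named here, with no measured step to lean on, the expectation rests on the counted difference alone: the isopropoxy group leaves and a diethylamino group enters on the carbonyl carbon. A step of a number 1.25 log units lower from compound 1 to compound 4 (beyond the scatter) is expected in this assay, downward. For compound 4 the estimate in this assay is 5.9, within a range from 5.2 to 6.6.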

Compound 4, partition coefficient: 6.02
Compound 4: the middle estimate sits 0.12 log units below what was measured, and the stated range covers the measured number.
By their numbers in this assay, from the lowest: compound 3; then compound 4; then compound 2; then compound 1.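

In this assay, the carbonyl end of the chain proves able to move the number: diethylamino in place of isopropoxy on the carbonyl carbon gives a number 1.13 log units lower from compound 1 to compound 4 (beyond the scatter) and so counts as a large step. The earlier compounds shown here varied only the saturated end of the chain, so they could not show whether the opposite end mattered at all. Among the compounds shown here, measured from the same compound, this change is larger than a number 0.38 log units lower from compound 1 to compound 2 (beyond the scatter) and smaller than a number 2.40 log units lower from compound 1 to compound 3 (beyond the scatter) at the far end, so neither end of the chain is the only place where this number can shift.

For the compounds shown here, with only one pair at the carbonyl carbon, a dimethylamino group, a pyrrolidine amide or a free carboxylic acid in that place would be needed to show how the number follows the group there, and the same swap on the far-end groups of compound 2 or compound 3 would show whether the step carries over to them. Nothing measured here explains why the number falls with this change.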